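The source may report more compounds than this note shows. Statements on the series, on what has been measured and on what is new or still open speak of the compounds shown alone.

Compound 1, `Cc1cc(NC(=O)Nc2cccc([N+](=O)[O-])c2)c2ccccc2n1`: in an ADME assay on HEK293 cells (Homo sapiens) for cytotoxicity, with a stated time of 72 h (on this read-out higher numbers stand for an effect only at larger amounts of compound and lower numbers for an effect already at smaller amounts), compound 1 gives > 25000 nM, which is a limit of the assay.
Compound 2, `Cc1cc(NC(=O)Nc2ccc(OC(F)(F)F)cc2)c2ccccc2n1`: in this assay compound 2 gives 14000 nM.
Compound 3, `Cc1cc(NC(=O)Nc2cccnc2)c2ccccc2n1`: in this assay compound 3 gives > 25000 nM, again a limit of the assay.

Compound 1 thus stands at the edge of what this assay reports: the limit of > 25000 nM in this assay, at which 2 of the 3 values shown sit. Only compound 2 gives a number at all, and it lies not far from that edge. Compound 4, `Cc1cc(NC(=O)Nc2cccc(C(C)(C)C)c2)c2ccccc2n1`, differs from compound 1 in one place: tert-butyl in place of nitro on an aromatic carbon. Within the data shown here, no step between two measured compounds is available to show how such a change shifts this assay, so no step beyond the usual scatter is expected in either direction. Compound 4 is therefore expected to give about 25000 nM, somewhere between 10000 nM and 60000 nM. The expected step of a number no higher from compound 1 to compound 4 (the limit leaves the size open) is essentially none.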

Compound 4, half-maximal effective concentration: > 25000 nM
Compound 4 gave a limit, no number (the forecaster's own chance of this, stated with the estimate: 65%); the middle value sits exactly at the limit.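

Compound 1 and compound 4 both end at a limit rather than a number, so no step between them can be read: the limit of > 25000 nM in this assay, at which 3 of the 4 values shown sit.

The compounds shown leave open how far tert-butyl in place of nitro on an aromatic carbon shifts the result in this assay.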